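A few compounds are considered here, and "the series" means these few. Any claim that something is new, unique, unknown or untested is made for them only; others in the source may bear on it.

Compound 2 `CSc1ccc(CNc2nc(SC)nc3ccccc23)cc1` stands at the upper edge of what has been measured so far. In an ADME assay on 184B5 cells (Homo sapiens) for cytotoxicity, read by MTT assay, with a stated time of 72 h (a higher number here means a weaker inhibitor of growth, a lower number a stronger inhibitor of growth), compound 2 gives only a limit, > 100000 nM. Its nearest measured neighbour is compound 1 `CSc1ccc(CNc2nc([SeH])nc3ccccc23)cc1`, which in this assay gives 86300 nM. The step of an at least 1.1-fold higher number from compound 1 to compound 2 (0.06 log units; that floor lies within the scatter) thus shows nothing beyond the scatter between the two. The change now considered leads to compound 3 `CSc1ccc(CNc2nc([Se]C)nc3ccccc23)cc1`, in which (a group of 2 heavy atoms (1 carbon, 1 selenium; no ring) in place of a group of 2 heavy atoms (1 carbon, 1 sulfur; no ring), on an aromatic carbon). Going by the values given here, only one measured step bears on this change, an at least 1.1-fold higher number from compound 1 to compound 2 (0.06 log units; that floor lies within the scatter), and it was small; it sits at the same aromatic carbon and suggests no movement beyond the scatter, in either direction. Given (the limit of > 100000 nM in this assay, at which 1 of the 2 values shown sits), compound 3 may again yield only a limit rather than a number. Compound 3 is therefore expected to give 120000 nM in this assay, within a range from 50000 nM to 300000 nM. The step that the limit leaves unreadable from compound 2 to compound 3 is expected to stay within the scatter.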

Compound 3, concentration for total growth inhibition: > 100000 nM
Compound 3: no number, only a limit (the forecaster's own chance of this, stated with the estimate: 60%); the middle value is on the limit's open side.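

At this aromatic carbon between two ring nitrogen atoms, placing the group of 1 carbon and 1 selenium where methylsulfanyl stood gives a second limit in this assay, so the step between compound 2 and compound 3 cannot be read. Methyl in place of hydrogen on the selenium gives an at least 1.1-fold higher number from compound 1 to compound 3 (0.06 log units; that floor lies within the scatter), so this second change at the position also shows no movement beyond the scatter. Readings at this position now mostly end in a limit: the limit of > 100000 nM in this assay, at which 2 of the 3 values shown sit.

On these data alone, whether methylsulfanyl and the selenium-bearing group differ at all in this assay remains open. As far as these compounds go, it is also open whether an amine, a carboxylic acid or a longer chain on this carbon would give a number rather than a limit.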